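This account rests on a few compounds, and the source may have more. Where it says the series, first, only, none or still open, it means among the compounds named here.

Working notes on the chalcone-type series built on the shared core of compound 1, structure `Cn1cccc1C(=O)/C=C/c1ccc2c(c1)B(O)OC2`. In a functional assay on MDA-MB-231 cells (Homo sapiens) for cytotoxicity, read by MTT assay, with a stated time of 48 h (on this read-out lower numbers stand for stronger inhibition and higher numbers for weaker inhibition), compound 1 gives only a limit of the assay, > 100000 nM, and no number. The second member carrying this core, compound 2 with structure `O=C(/C=C/c1ccc2c(c1)B(O)OC2)c1ccc(OCc2ccccc2)cc1`, gives 5300 nM in this assay. What these two values show is that compound 1 sits at the limit of > 100000 nM in this assay, at which 1 of the 2 values shown sits, while compound 2 gives a number within the range of the assay.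

The next compound to be examined is compound 3, structure `O=C(/C=C/c1ccc2c(c1)B(O)OC2)c1cccc(F)c1`. It differs from compound 1 in one place: 3-fluorophenyl in place of 1-methyl-1H-pyrrol-2-yl on a carbonyl carbon. For the measured compounds named here, no step between measured compounds is available for this change, so the expectation rests on the two values shown. The step from compound 1 to compound 3 is expected to run toward stronger inhibition, an at least 5.0-fold lower number from compound 1 to compound 3 (0.69 log units; beyond the scatter), since the starting point is only a limit. For compound 3 the estimate in this assay is 20000 nM, within a range from 5000 nM to 100000 nM.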

Compound 3, half-maximal inhibitory concentration: 3000 nM
Estimate against measurement, compound 3: 6.7-fold (0.82 log units) above; the measured number lies below the stated range.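

In this assay, for the compounds shown here, 3-fluorophenyl in place of 1-methyl-1H-pyrrol-2-yl on a carbonyl carbon gives the first readable step, an at least 33-fold lower number from compound 1 to compound 3 (1.52 log units; beyond the scatter). This shows that the group at this position can decide whether the series gives a number within the range of the assay at all, and that a small aryl group can do so, with no benzyloxy-bearing ring needed. The true size of the step stays unknown, since compound 1 stands at a limit of the assay and not at a number: the limit of > 100000 nM in this assay, at which 1 of the 3 values shown sits.

Open, on these data alone, is whether the step belongs to the phenyl ring or to its fluorine, which a phenyl without fluorine, or one carrying an amine or a carboxylic acid instead, would separate. Also open, as far as these compounds go, is how a five-membered aromatic ring without the methyl on nitrogen would read here.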